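The source may hold more compounds than are shown below. What is called first, only, known or untested is meant among the compounds shown, and "the series" means these compounds.

Measured compounds in a functional assay on MCF7 cells (Homo sapiens) for cytotoxicity, read by MTT assay, with a stated time of 24 h; on this read-out higher numbers stand for weaker inhibition and lower numbers for stronger inhibition:

Compound 1, `Cn1nc(-c2nnc(SCCc3ccc(F)cc3)o2)cc1-c1ccc(C(F)(F)F)cc1`, gives 25200 nM.
Compound 2, `Cn1nc(-c2nnc(SCc3cccc([N+](=O)[O-])c3)o2)cc1-c1ccc(C(F)(F)F)cc1`, reaches only the limit of this assay at > 100000 nM.
Compound 3, `Cn1nc(-c2ccc(C(F)(F)F)cc2)cc1-c1nnc(SCCc2ccc(F)cc2)o1`, gives 45400 nM.

Compound 1 and compound 3 are built from the same atoms joined differently; the difference between the two cores is not broken down here. Their two values lie within the scatter of each other, so no order is read between compound 1 and compound 3.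

From compound 1 to compound 2 the change is 3-nitrophenyl in place of 4-fluorobenzyl on a saturated chain carbon bound to a sulfur. The step is an at least 3.9-fold higher number from compound 1 to compound 2 (0.59 log units; beyond the scatter), and its size is only a lower bound, since compound 2 sits at the limit described as the limit of > 100000 nM in this assay, at which 1 of the 3 values shown sits.

Compound 4, `Cn1nc(-c2ccc(C(F)(F)F)cc2)cc1-c1nnc(SCc2cccc([N+](=O)[O-])c2)o1`, is not yet measured in this assay. It differs from compound 3 by 3-nitrophenyl in place of 4-fluorobenzyl on a saturated chain carbon bound to a sulfur, which is the same change as that from compound 1 to compound 2, made on the core of compound 3 instead of the core of compound 1.

On this basis a step of similar direction and size is expected from compound 3 to compound 4, namely a 3.5-fold higher number from compound 3 to compound 4 (0.55 log units; beyond the scatter), because the same change gave an at least 3.9-fold higher number from compound 1 to compound 2 (0.59 log units; beyond the scatter). Starting from the value of compound 3, such a step would carry compound 4 to the region of the assay limit, so an estimate of 160000 nM is given for compound 4, with a range from 60000 nM to 400000 nM, and a substantial chance that only a limit is reported.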

Compound 4, half-maximal inhibitory concentration: > 100000 nM
Compound 4 gave a limit, no number (the forecaster's own chance of this, stated with the estimate: 65%); the middle value is on the limit's open side.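

In this assay compound 4 gives > 100000 nM, which is a limit of the assay and not a number. Carried to the core of compound 3, 3-nitrophenyl in place of 4-fluorobenzyl on a saturated chain carbon bound to a sulfur gives an at least 2.2-fold higher number from compound 3 to compound 4 (0.34 log units; beyond the scatter), so on the two cores shown the change goes in one direction, towards weaker inhibition, and this holds for these two pairs only. It does not show that the change has the same size on both cores, since each step is only a lower bound: the same change on two cores in this assay, an at least 3.9-fold higher number (0.59 log units; beyond the scatter) from compound 1 to compound 2 and an at least 2.2-fold higher number (0.34 log units; beyond the scatter) from compound 3 to compound 4; the limit leaves it open whether they differ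

How weak the compounds carrying 3-nitrobenzyl really are stays open, and so does any ranking among them, as the read-out gives no number for them: the limit of > 100000 nM in this assay, at which 2 of the 4 values shown sit. The change replaces 2-(4-fluorophenyl)ethyl with 3-nitrobenzyl in a single move, so the compounds shown do not separate the contribution of the nitro group from that of the chain, and it remains open how the two cores would respond to an amine or a carboxylic acid in place of the nitro group, or to a longer chain.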